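The source may report more compounds than this note shows. Statements on the series, on what has been measured and on what is new or still open speak of the compounds shown alone.

In an ADME assay on Vero cells (Chlorocebus sabaeus) for cytotoxicity, read by WST assay (a lower number here means that less compound is tolerated, a higher number that more compound is tolerated), compound 2 `O=c1[nH]c(Nc2cc(F)cc(F)c2)nc2cc(C(F)(F)F)ccc12` gives >= 7600 nM, which is a limit of the assay rather than a number. Compound 1 `O=c1[nH]c(Nc2cc(Cl)cc(Cl)c2)nc2cc(Cl)ccc12` gives > 25000 nM, also a limit. Compound 3 `Nc1ccc2c(=O)[nH]c(Nc3cc(F)cc(F)c3)nc2c1` gives > 25000 nM, again a limit. Going by these compounds, the step from compound 2 to compound 3 is a step that the two limits leave unreadable from compound 2 to compound 3, so its size stays unknown. Compound 4 `O=c1[nH]c(Nc2cc(Cl)cc(Cl)c2)nc2cc(C(F)(F)F)ccc12` differs from compound 2 by 3,5-dichlorophenyl in place of 3,5-difluorophenyl on a nitrogen on an aromatic ring. Going by the values given here, no measured step covers this exchange; the two limits, the limit of > 25000 nM in this assay, at which 2 of the 3 values shown sit, and (the limit of >= 7600 nM in this assay, at which 1 of the 3 values shown sits), show only that every compound so far is tolerated up to the edge of the assay. The step that the limit leaves unreadable from compound 2 to compound 4 that the estimate means is therefore expected to stay within the scatter. The expected value for compound 4 is 20000 nM, between 6000 nM and 60000 nM.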

Compound 4, half-maximal cytotoxic concentration: 7100 nM
The estimate for compound 4 lay 2.8-fold (0.45 log units) above the measured number; measured number inside the range.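

In this assay compound 4 is the only compound shown that gives a number rather than a limit. Going by these compounds alone, putting 3,5-dichlorophenyl in place of 3,5-difluorophenyl on the nitrogen gives an at least 1.0-fold lower number from compound 2 to compound 4 (0.02 log units; that floor lies within the scatter), which is only a floor because compound 2 carries a limit: the limit of >= 7600 nM in this assay, at which 1 of the 4 values shown sits. Putting trifluoromethyl in place of chloro on the aromatic carbon, with 3,5-dichlorophenyl kept, gives an at least 3.5-fold lower number from compound 1 to compound 4 (0.54 log units; beyond the scatter), the first step in this assay readable beyond the scatter.

Going by these compounds, the true size of the first exchange stays open. So does whether a nitrile or a carboxylic acid on that aromatic carbon would also lower the number.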